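A few compounds are considered here, and "the series" means these few. Any claim that something is new, unique, unknown or untested is made for them only; others in the source may bear on it.

Measured compounds, with their values in an assay on isolated protein for inhibition of Amine oxidase [flavin-containing] A (Homo sapiens), read by fluorescence and Amplex Red, with a stated time of 30 min, tested at 0.01 uM; a lower number here means a weaker effect, a higher number a stronger effect of the compound at the concentration tested:

Compound 1, `CCCCNc1nnc(SCC(=O)N(Cc2cccc([N+](=O)[O-])c2)c2ccc(F)cc2)s1`, gives 30%.
Compound 2, `COCCNc1nnc(SCC(=O)N(Cc2cccc([N+](=O)[O-])c2)c2ccc(F)cc2)s1`, gives 34.8%.
Compound 3, `CC(C)Nc1nnc(SCC(=O)N(Cc2cccc([N+](=O)[O-])c2)c2ccc(F)cc2)s1`, gives 23.9%.

Compound 3 stands lowest of the three numbers shown. Its nearest neighbour is compound 1, a step of a number 6.1 percentage points lower from compound 1 to compound 3 (within the scatter), which lies within the scatter; its furthest is compound 2, a step of a number 10.9 percentage points lower from compound 2 to compound 3 (beyond the scatter), which lies beyond the scatter but is modest.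

Compound 4, `CCNc1nnc(SCC(=O)N(Cc2cccc([N+](=O)[O-])c2)c2ccc(F)cc2)s1`, has not yet been measured in this assay. It differs from compound 3 in one place: hydrogen in place of methyl on a saturated chain carbon bound to a nitrogen on an aromatic ring and a saturated chain carbon. The group on the nitrogen on the aromatic ring thus shrinks once more, as it did from compound 1 to compound 3, where the step was a number 6.1 percentage points lower from compound 1 to compound 3 (within the scatter). That earlier step in the same direction stayed within the scatter, and the spread among all three measured compounds is small. The step from compound 3 to compound 4 is therefore expected to be a number 3.1 percentage points higher from compound 3 to compound 4 (within the scatter), that is, nothing clearly beyond the scatter. Compound 4 is estimated to give about 27% in this assay, with a likely range from 15% to 40%.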

Compound 4, a percentage reported as inhibition, at one concentration (the size of the read-out at that concentration, not a potency): 30.3%
Compound 4: the middle estimate sits 3.3 percentage points below what was measured, and the stated range covers the measured number.
By their numbers in this assay, from the lowest: compounds 3, 1, 4 and 2 (each within the scatter of the next, the first and the last beyond it).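

In this assay, taking one methyl off the isopropyl group to leave ethyl gives a number 6.4 percentage points higher from compound 3 to compound 4 (within the scatter), so the loss of this branch point on the nitrogen does not register as a readable change. Ethyl also cannot be told apart from the longer groups at this position: butyl gives a number 0.3 percentage points higher from compound 1 to compound 4 (within the scatter), and 2-methoxyethyl gives a number 4.5 percentage points lower from compound 2 to compound 4 (within the scatter), so compound 4 lies within the scatter of all three earlier compounds, and the only gap beyond it remains a number 10.9 percentage points lower from compound 2 to compound 3 (beyond the scatter). No independent data bear on what lies behind these small differences.

As far as these compounds go, all four compounds carry small open-chain groups on this nitrogen and share the rest of the structure, so it remains open whether a cyclohexyl ring, a benzyl group, a chain ending in an amine or one ending in a carboxylic acid would move the number clearly beyond the scatter. The read-out comes from a single concentration, so it speaks only of a stronger or weaker effect at that concentration.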